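This account rests on a few compounds, and the source may have more. Where it says the series, first, only, none or still open, it means among the compounds named here.

Among the measured compounds shown here, compound 2 `COc1cccc(C(=O)NCCNc2cccc(NS(=O)(=O)c3cc(-c4cccc(C(=O)N(C)C)c4)ccc3OC)c2)c1` gives 33 nM in an assay on CHO-K1 cells for agonist activity at Orexin receptor type 2 (Homo sapiens), read by a luciferase reporter (a higher number here means that more compound is needed for the effect, a lower number that less compound is needed), the lowest of the two numbers measured so far; the nearest is compound 1 `COc1ccccc1C(=O)NCCNc1cccc(NS(=O)(=O)c2cc(-c3cccc(C(=O)N(C)C)c3)ccc2OC)c1`, which in this assay gives 50 nM. For the measured compounds named here, the one measured step, a 1.5-fold lower number from compound 1 to compound 2 (0.18 log units; within the scatter), changes only the position of a methoxy on the carbonyl-bearing ring and stays within the scatter.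

Compound 3 `COc1ccc(-c2cccc(C(=O)N(C)C)c2)cc1S(=O)(=O)Nc1cccc(NCCNC(=O)c2cccc(Cl)c2)c1` is not yet measured. It differs from compound 2 by chloro in place of methoxy on an aromatic carbon. Going by the values given here, no measured step exchanges a methoxy for a chloro, so the step from compound 1 to compound 2 bears on it only indirectly, by showing that a change on this same ring moved the number little. For compound 3 the expectation is a step of a 1.1-fold higher number from compound 2 to compound 3 (0.03 log units; within the scatter) in this assay, with no direction favoured beyond the scatter. The estimate for compound 3 is therefore 35 nM, in the range 12 nM to 100 nM.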

Compound 3, half-maximal effective concentration: 94 nM
Compound 3: middle estimate off by 2.7-fold (0.43 log units), on the low side, within the range that was stated.
By their numbers in this assay, from the lowest: compounds 2, 1 and 3 (each within the scatter of the next, the first and the last beyond it).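

On the ring of the 3-methoxyphenyl group, the exchange of methoxy for chloro is the first change shown to pass the scatter in this assay (a 2.8-fold higher number from compound 2 to compound 3 (0.45 log units; beyond the scatter)), so the group at this place can matter where the earlier shift of methoxy alone did not show that. The effect is modest, and the other new step (a 1.9-fold higher number from compound 1 to compound 3 (0.27 log units; within the scatter)) stays within the scatter, so compound 3 cannot be told apart from compound 1. No measured evidence explains the step from methoxy to chloro.

The compounds shown carry only methoxy and chloro on this ring, so it stays open whether the number follows the particular group or the presence of methoxy. A fluoro, methyl, hydroxy or dimethylamino group at the same place, and a 2-chlorophenyl group, would bear on that.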